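Permeability notes: amide variation at the piperidine carbonyl

The source may hold more compounds than are shown below. What is called first, only, known or untested is meant among the compounds shown, and "the series" means these compounds.

The series shares one core, shown in compound 1 `Cn1cncc1CN1CC(N(CC2CCN(C(=O)Nc3ccc(Br)cc3)CC2)S(=O)(=O)c2ccccn2)Cc2cc(C#N)ccc21`, compound 2 `Cn1cncc1CN1CC(N(Cc2ccc(S(C)(=O)=O)cc2)S(=O)(=O)c2ccccn2)Cc2cc(C#N)ccc21` and compound 3 `Cn1cncc1CN1CC(N(Cc2cccc(-n3cccc3)c2)S(=O)(=O)c2ccccn2)Cc2cc(C#N)ccc21`, differing in the group on the saturated chain carbon bound to the sulfonamide nitrogen. In an ADME assay on Caco-2 cells (Homo sapiens) for permeability, in the apical to basolateral direction (on this read-out higher numbers stand for higher permeability and lower numbers for lower permeability), compound 1 gives 0.6 10^-6 cm/s, compound 2 gives 0.2 10^-6 cm/s and compound 3 gives 2.3 10^-6 cm/s. Compound 1 thus stands second of the three numbers, between compound 2 and compound 3. Among the compounds with values here, the one step that connects two measured compounds, a 12-fold higher number from compound 2 to compound 3 (1.06 log units; beyond the scatter), concerns the aryl group itself and is the only indication so far of how far a change in this region can move the read-out.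

Compound 4 `Cn1cncc1CN1CC(N(CC2CCN(C(=O)CC(C)(C)C)CC2)S(=O)(=O)c2ccccn2)Cc2cc(C#N)ccc21` keeps the piperidine-bearing chain of compound 1 and differs only at the carbonyl carbon: neopentyl in place of (4-bromophenyl)amino on a carbonyl carbon. Within the data shown here, no measured step alters the carbonyl substituent, so no step bears directly on this change, and the expectation rests on the value of compound 1 with a wide range. A step of modest size upward is expected, a 2.5-fold higher number from compound 1 to compound 4 (0.40 log units; beyond the scatter), though a result within the scatter of compound 1 would not surprise. The estimate for compound 4 in this assay is 1.5 10^-6 cm/s, expected between 0.4 10^-6 cm/s and 5 10^-6 cm/s.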

Compound 4, apparent permeability: 0.5 10^-6 cm/s
For compound 4 the middle estimate is 3.0-fold (0.48 log units) above the measured one; low and high end bracket the measured number.
By their numbers in this assay, from the lowest: compound 2; then compounds 4 and 1 (each within the scatter of the next); then compound 3.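

In this assay the exchange at this carbonyl carbon gives a 1.2-fold lower number from compound 1 to compound 4 (0.08 log units; within the scatter) as neopentyl replaces (4-bromophenyl)amino, so this pair offers no basis for ordering the two compounds. The change removes the six-membered aromatic ring and the hydrogen-bond donor of the leaving group, and the read-out still shows no difference beyond the scatter. The earlier step of a 12-fold higher number from compound 2 to compound 3 (1.06 log units; beyond the scatter) concerns a different place and lies beyond the scatter, whereas this first comparison on the carbonyl carbon does not; no measurement bears on why the read-out stays level here.

With only (4-bromophenyl)amino and neopentyl compared on this carbonyl carbon, the result describes one pair and does not establish a trend for the position as a whole. Going by these compounds, it remains open how the read-out responds to an unsubstituted phenylamino group, a longer alkyl chain, or a chain ending in an amine or a carboxylic acid at this carbonyl carbon.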